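Swapping a Sec-Butyl for a Cyclohexyl on the Amine

A few compounds are considered here, and "the series" means these few. Any claim that something is new, unique, unknown or untested is made for them only; others in the source may bear on it.

Compound 2 `CCC(C)NC(=C\C(=O)/C=C/c1ccc(O)cc1)/C=C/c1ccc(O)cc1` carries a sec-butyl group on its amine nitrogen. In a functional assay on HT-29 cells (Homo sapiens) for inhibition, read by sulforhodamine B assay, with a stated time of 72 h (a higher number here means a weaker inhibitor, a lower number a stronger inhibitor), compound 2 gives 15600 nM. Compound 3 `CCC(C)NC(=C\C(=O)/C=C/c1ccc(OC(C)=O)c(OC)c1)/C=C/c1ccc(OC(C)=O)c(OC)c1` has the same sec-butyl amine on another core; the difference between the two cores is not broken down here. In this assay compound 3 reaches only a limit of the assay, > 25000 nM. Compound 1 `COc1cc(/C=C/C(=O)/C=C(/C=C/c2ccc(OC(C)=O)c(OC)c2)NC2CCCCC2)ccc1OC(C)=O` is compound 3 with cyclohexyl in place of sec-butyl on an amine nitrogen. Compound 1 likewise reaches only a limit of the assay, > 25000 nM. The step that the two limits leave unreadable from compound 3 to compound 1 therefore cannot be read, because the limit of > 25000 nM in this assay, at which 2 of the 3 values shown sit, hides both ends. Compound 4 `O=C(/C=C(/C=C/c1ccc(O)cc1)NC1CCCCC1)/C=C/c1ccc(O)cc1` is compound 2 with the same change, (cyclohexyl in place of sec-butyl on an amine nitrogen). With the measured pair giving no readable size, the expected step is small, a 1.3-fold lower number from compound 2 to compound 4 (0.11 log units; within the scatter), resting only on compound 2 at 15600 nM. Compound 4 is therefore estimated at 12000 nM, between 5000 nM and 30000 nM.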

Compound 4, half-maximal inhibitory concentration: 5900 nM
Estimate against measurement, compound 4: 2.0-fold (0.31 log units) above; the range from low to high includes it.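

In this assay, cyclohexyl in place of sec-butyl on an amine nitrogen gives a 2.6-fold lower number from compound 2 to compound 4 (0.42 log units; beyond the scatter), a modest gain in strength on this one core. The same change on the core of compound 3 cannot be read, because compound 3 and compound 1 both stand only at a limit of the assay: the limit of > 25000 nM in this assay, at which 2 of the 4 values shown sit. This leaves a single readable pair, so it does not show whether the gain carries from one core to the other.

The compounds shown leave open how other groups on this nitrogen would behave, such as cyclopentyl or benzyl. An open-chain hexyl group could help separate the effect of the ring from that of the added carbons.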